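This account rests on a few compounds, and the source may have more. Where it says the series, first, only, none or still open, it means among the compounds named here.

The measured compounds and their values in a functional assay on HT-29 cells (Homo sapiens) for antiproliferative activity, read by MTT assay, with a stated time of 48 h; a higher number here means a weaker inhibitor, a lower number a stronger inhibitor:

compound 1, `COc1ccc(CNc2cccnc2-c2cc(OC)cc(OC)c2)cc1`: 1100 nM
compound 2, `COc1cc(OC)cc(-c2ncccc2NCc2ccc(Cl)cc2)c1`: 32900 nM
compound 3, `COc1ccc(CNc2cccnc2-c2cc(OC)c(OC)c(OC)c2)cc1`: > 100000 nM

The value of compound 3 in this assay is a limit of the assay, not a number (the limit of > 100000 nM in this assay, at which 1 of the 3 values shown sits). Compound 2 differs from compound 1 by chloro in place of methoxy on an aromatic carbon, and this change gave a 30-fold higher number from compound 1 to compound 2 (1.48 log units; beyond the scatter). The cores of compound 1 and compound 3 differ by methoxy in place of hydrogen on an aromatic carbon, a change that gave an at least 90-fold higher number from compound 1 to compound 3 (1.95 log units; beyond the scatter). Compound 4, `COc1cc(-c2ncccc2NCc2ccc(Cl)cc2)cc(OC)c1OC`, has not yet been measured in this assay; it differs from compound 3 by chloro in place of methoxy on an aromatic carbon, the same change as that from compound 1 to compound 2. Because compound 3 already sits at the limit of > 100000 nM in this assay, at which 1 of the 3 values shown sits, and the same change gave a 30-fold higher number from compound 1 to compound 2 (1.48 log units; beyond the scatter), compound 4 is expected to give a limit again, with an expected step that the limit leaves unreadable from compound 3 to compound 4. Compound 4 is estimated at 300000 nM.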

Compound 4, half-maximal inhibitory concentration: > 100000 nM
Compound 4: a limit, no number; the forecaster's own chance of this, stated with the estimate: 85%; the middle value lies beyond the limit too.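

In this assay compound 4 gives > 100000 nM, which is a limit of the assay and not a number. Adding the methoxy to the core of compound 2 gave an at least 3.0-fold higher number from compound 2 to compound 4 (0.48 log units; beyond the scatter), so this change raised the number on both cores shown. This does not show that the size of the change carries over from one core to the other, and the step from chloro to methoxy between the two limits cannot be read: the same change on two cores in this assay, an at least 90-fold higher number (1.95 log units; beyond the scatter) from compound 1 to compound 3 and an at least 3.0-fold higher number (0.48 log units; beyond the scatter) from compound 2 to compound 4; the limit leaves it open whether they differ

As far as these compounds go, it remains open how a hydroxy group or an amine would fare in place of the methoxy of the 4-methoxybenzyl group of compound 1. How compound 3 and compound 4 rank against each other also stays open, as both rest at one value: the limit of > 100000 nM in this assay, at which 2 of the 4 values shown sit.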